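Swapping a fluorinated phenyl for a chlorinated one

The compounds below may be only part of what the source reports. "The series", "measured", "known", "first", "only" and "open" are said of these compounds alone.

Compound 3 `O=C1C=C(C(O)c2ccc(F)cc2)C(=O)c2ccccc21` stands second highest of the three numbers measured in a functional assay on WHCO1 cells (Homo sapiens) for cytotoxicity, read by MTT assay, with a stated time of 24 h (on this read-out higher numbers stand for weaker inhibition and lower numbers for stronger inhibition), where compound 3 gives 5100 nM. Its nearest neighbour is compound 1 `CC(O)C1=CC(=O)c2ccccc2C1=O`, which gives 6400 nM; the furthest is compound 2 `O=C1C=C(C(O)c2ccccc2)C(=O)c2ccccc21`, which gives 3900 nM. All three lie within the scatter of one another: a 1.6-fold lower number from compound 1 to compound 2 (0.22 log units; within the scatter), a 1.3-fold lower number from compound 1 to compound 3 (0.10 log units; within the scatter) and a 1.3-fold higher number from compound 2 to compound 3 (0.12 log units; within the scatter). Compound 4 `O=C1C=C(C(O)c2cccc(Cl)c2)C(=O)c2ccccc21` has not yet been measured. The change is 3-chlorophenyl in place of 4-fluorophenyl on a saturated chain carbon bound to a double-bonded ring carbon and an oxygen on a saturated carbon. The step that bears most directly on it is a 1.3-fold higher number from compound 2 to compound 3 (0.12 log units; within the scatter), which stayed within the scatter, so putting a fluorine on the phenyl made no difference beyond noise. Going by the values given here, no measured step exchanges one halogen for another or changes which carbon of the phenyl carries it, so nothing here points to a step beyond the scatter. In this assay compound 4 is therefore expected to give about 4500 nM, with a range from 2000 nM to 10000 nM. The expected step is a 1.1-fold lower number from compound 3 to compound 4 (0.05 log units; within the scatter), essentially none beyond the scatter.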

Compound 4, half-maximal inhibitory concentration: 7300 nM
For compound 4 the middle estimate is 1.6-fold (0.21 log units) below the measured one, and the stated range covers the measured number.
By their numbers in this assay, from the lowest: compounds 2, 3, 1 and 4 (each within the scatter of the next).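

In this assay, 3-chlorophenyl in place of 4-fluorophenyl at this position gave (a 1.4-fold higher number from compound 3 to compound 4 (0.16 log units; within the scatter)), showing that changing the halogen and the carbon carrying it together stays inside the scatter. The other two comparisons read the same way: chloro in place of hydrogen gave (a 1.9-fold higher number from compound 2 to compound 4 (0.27 log units; within the scatter)), and 3-chlorophenyl in place of methyl gave (a 1.1-fold higher number from compound 1 to compound 4 (0.06 log units; within the scatter)), so methyl, phenyl and both halogenated phenyls on this saturated chain carbon cannot be told apart in this read-out. No measurement offered here explains this result.

On these data alone, since the halogen and its carbon changed in one step, what each contributes separately stays open. Also open, as far as these compounds go, is whether an amine, a carboxylic acid or a longer chain in place of these groups would give a step beyond the scatter.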